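Sugar-linked oxadiazoles: weak growth inhibitors on the shared core

The source may report more compounds than this note shows. Statements on the series, on what has been measured and on what is new or still open speak of the compounds shown alone.

Measured so far:
compound 1, `Nc1nnc(SC[C@H]2O[C@@H](OCc3noc(-c4ccc(Cl)cc4)n3)[C@@H]3OC4(CCCC4)O[C@@H]32)s1`: 16000 nM
compound 2, `CC(=O)OC[C@H]1O[C@@H](OCc2noc(-c3ccc([N+](=O)[O-])cc3)n2)[C@@H]2OC3(CCCC3)O[C@@H]21`: 17000 nM

In a functional assay on HeLa cells (Homo sapiens) for antiproliferative activity, read by sulforhodamine B assay, with a stated time of 48 h (on this read-out higher numbers stand for weaker inhibition of growth and lower numbers for stronger inhibition of growth), compound 2 gives 17000 nM and holds the highest number of the two, with compound 1 close by; the two values lie within the scatter, so no order between them is claimed. Within the data shown here, no step between measured compounds is at hand. Compound 3, `O=[N+]([O-])c1ccc(-c2nc(CO[C@@H]3O[C@H](CSc4ncn[nH]4)[C@H]4OC5(CCCC5)O[C@@H]34)no2)cc1`, changes compound 2 in one place: (1H-1,2,4-triazol-5-yl)sulfanyl in place of acetoxy on a saturated chain carbon bound to a saturated ring carbon. Both measured compounds sit at weak inhibition whatever group occupies this position, so for compound 3 a step of a 1.1-fold lower number from compound 2 to compound 3 (0.03 log units; within the scatter) is expected, none beyond the scatter in either direction. Compound 3 is thus estimated at 16000 nM, within 6000 nM to 45000 nM.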

Compound 3, concentration for 50% growth inhibition: 20000 nM
Beside the measured number, compound 3's estimate is 1.3-fold (0.10 log units) below it; the range from low to high includes it.
By their numbers in this assay, from the lowest: compounds 1, 2 and 3 (each within the scatter of the next).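

In this assay, among these compounds, the first direct reading at this position gives a 1.2-fold higher number from compound 2 to compound 3 (0.07 log units; within the scatter) for (1H-1,2,4-triazol-5-yl)sulfanyl in place of acetoxy on a saturated chain carbon bound to a saturated ring carbon. A five-membered aromatic ring carrying a hydrogen-bond donor therefore replaces acetoxy, which has no ring and no donor, without a step beyond the scatter. No available measurement accounts for this result. On these data alone, whether an amine, a carboxylic acid or a free hydroxyl at this position would give a step beyond the scatter remains open. As far as these compounds go, whether any group here gives stronger inhibition of growth also remains open.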